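This account rests on a few compounds, and the source may have more. Where it says the series, first, only, none or still open, it means among the compounds named here.

Measured in an ADME assay on HEK293 cells (Homo sapiens) for cytotoxicity, read by resazurin assay, with a stated time of 48 h; on this read-out lower numbers stand for higher toxicity in this test and higher numbers for lower toxicity in this test:
- compound 1 `CCc1ccc(S(=O)(=O)Nc2ccc(-c3nc4ccccc4o3)cc2)cc1` gives 82000 nM
- compound 2 `O=S(=O)(Nc1ccc(-c2nc3ccccc3o2)cc1)c1ccc(Cl)c(Cl)c1` gives > 100000 nM, a limit of the assay and not a number

Compound 2 is therefore known only by a limit, (the limit of > 100000 nM in this assay, at which 1 of the 2 values shown sits). Compound 3 `O=S(=O)(Nc1ccc(-c2nc3ccccc3o2)cc1)c1ccc(Cl)cc1` has hydrogen in place of chloro on an aromatic carbon, 3,4-dichlorophenyl becoming 4-chlorophenyl (hydrogen in place of chloro on an aromatic carbon). Among the compounds with values here, the one measured step that bears on this is an at least 1.2-fold higher number from compound 1 to compound 2 (0.08 log units; that floor lies within the scatter), and it changes the same group without passing the scatter. No step beyond the scatter, in either direction, is therefore expected in this assay. The estimate for this change is an at least 1.1-fold lower number from compound 2 to compound 3 (0.04 log units; that floor lies within the scatter). Compound 3 is expected at 90000 nM, with an estimated range of 45000 nM to 180000 nM.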

Compound 3, half-maximal cytotoxic concentration: > 100000 nM
Compound 3: a limit, no number; the forecaster's own chance of this, stated with the estimate: 45%; middle value at least 1.1-fold (0.04 log units) from the limit.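

In this assay compound 3 gives > 100000 nM, a limit of the assay and not a number. The step for chloro in place of ethyl on an aromatic carbon is an at least 1.2-fold higher number from compound 1 to compound 3 (0.08 log units; that floor lies within the scatter). The step that takes away one chloro cannot be read, and the 3,4-dichlorophenyl and 4-chlorophenyl compounds stand at the same limit: the limit of > 100000 nM in this assay, at which 2 of the 3 values shown sit.

Going by these compounds, how far beyond that limit compound 2 and compound 3 lie stays open. So does whether an amine or a carboxylic acid in place of the remaining chloro would give a measurable number.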